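Two cyclohexyl amines, one pyridinylmethyl variant

The compounds below may be only part of what the source reports. "The series", "measured", "known", "first", "only" and "open" are said of these compounds alone.

The two measured compounds share a core with a nitrile and a trifluoromethyl-bearing benzylic amine. Compound 1 `N#Cc1cnc(NCc2cnccc2C(F)(F)F)cc1NC[C@H]1CC[C@@H](O)CC1` carries a (4-hydroxycyclohexyl)methyl group on the aromatic nitrogen; in an assay on isolated protein for inhibition of protein kinase C delta type (Homo sapiens), read by TR-FRET, with a stated time of 2 h (on this read-out lower numbers stand for stronger inhibition and higher numbers for weaker inhibition), compound 1 gives 500 nM. Compound 2 `N#Cc1cnc(NCc2ccccc2C(F)(F)F)cc1N[C@H]1CC[C@@H](C(N)=O)CC1` carries a carboxamide-bearing cyclohexyl directly on that nitrogen, and in this assay compound 2 gives 640 nM, a difference from compound 1 that lies within the usual scatter of this measurement. Going by the values given here, no single-point step between measured compounds is available.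

Compound 3 `CC1(C)C[C@@H](Nc2cc(NCc3cnccc3C(F)(F)F)ncc2C#N)CC[C@H]1O` is not yet measured. It differs from compound 1 in one place: 4-hydroxy-3,3-dimethylcyclohexyl in place of (4-hydroxycyclohexyl)methyl on a nitrogen on an aromatic ring. Since the direct attachment of a substituted cyclohexyl in compound 2 and the methylene-linked hydroxycyclohexyl in compound 1 give numbers within the scatter of each other, the step from compound 1 to compound 3 is expected to be small, a 1.2-fold lower number from compound 1 to compound 3 (0.08 log units; within the scatter), with no clear direction beyond the scatter. Compound 3 is therefore estimated at 420 nM, with a range from 130 nM to 1400 nM.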

Compound 3, half-maximal inhibitory concentration: 2400 nM
Estimate against measurement, compound 3: 5.7-fold (0.76 log units) below; the measured number lies above the stated range.
By their numbers in this assay, from the lowest: compounds 1 and 2 (each within the scatter of the next); then compound 3.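

In this assay, going by these compounds alone, the position on a nitrogen on an aromatic ring proves sensitive to this change: 4-hydroxy-3,3-dimethylcyclohexyl in place of (4-hydroxycyclohexyl)methyl gives a 4.8-fold higher number from compound 1 to compound 3 (0.68 log units; beyond the scatter), the first step that can be read. The two groups have the same counts of hydrogen-bond donors and acceptors and the same six-membered carbon ring, so these counts alone do not settle the number here. Nothing shown gives a measured basis for explaining the step.

The compounds shown leave open which part of the change carries the step, the lost methylene link or the 3,3-dimethyl pair. As far as these compounds go, a plain 4-hydroxycyclohexyl group on that nitrogen would separate the two, and whether an amine in place of the hydroxyl would behave alike also remains open.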